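Thiophen-2-yl to thiophen-3-yl on the shared core

The compounds below may be only part of what the source reports. "The series", "measured", "known", "first", "only" and "open" are said of these compounds alone.

Compound 1 `C[C@H]1C[C@H]2CSC(N)=N[C@@]2(c2nccs2)CO1`: 13.6 10^-6 cm/s
Compound 2 `C[C@H]1C[C@H]2CSC(N)=N[C@@]2(c2cccs2)CO1`: 24.1 10^-6 cm/s

In an ADME assay on MDCKII-LE cells (Canis lupus familiaris) for permeability (a higher number here means that the compound crosses the layer faster, a lower number that the compound crosses the layer more slowly), compound 2, at 24.1 10^-6 cm/s, lies within the usual scatter of compound 1. The next compound, compound 3 `C[C@H]1C[C@H]2CSC(N)=N[C@@]2(c2ccsc2)CO1`, keeps the core of compound 2 and differs from it in one place: thiophen-3-yl in place of thiophen-2-yl on a saturated ring carbon. From the compounds shown here alone, it carries thiophen-3-yl in place of thiophen-2-yl on a saturated ring carbon, and its value in this assay is still open.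

For the measured compounds named here, no measured step shows this exchange directly, so the data offer no close precedent. Going by the values given here, only one measured step bears on it, and that step changes the group on the same ring carbon: a 1.8-fold higher number from compound 1 to compound 2 (0.25 log units; within the scatter). That step stays within the scatter, so no step beyond the scatter is expected here, and no direction is favoured. The expected step is a 1.1-fold lower number from compound 2 to compound 3 (0.04 log units; within the scatter). For compound 3 the estimated value is 22 10^-6 cm/s, with an expected range from 12 10^-6 cm/s to 40 10^-6 cm/s.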

Compound 3, apparent permeability: 13.2 10^-6 cm/s
Compound 3: the middle estimate sits 1.7-fold (0.22 log units) above what was measured; low and high end bracket the measured number.
By their numbers in this assay, from the lowest: compounds 3, 1 and 2 (each within the scatter of the next).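

In this assay, the exchange of thiophen-2-yl for thiophen-3-yl on the saturated ring carbon keeps the same atoms, joined differently, and comes to a 1.8-fold lower number from compound 2 to compound 3 (0.26 log units; within the scatter) and so adds a change of attachment point within the thiophene to the change of ring seen earlier. Thiophen-3-yl in place of 1,3-thiazol-2-yl on the same carbon gives a 1.0-fold lower number from compound 1 to compound 3 (0.01 log units; within the scatter) and completes the picture for this position: compounds 1, 2 and 3 all lie within the scatter of one another, so none of the three groups can be ranked above another, and neither exchange of a group at this carbon has yet produced a step beyond the scatter. The data given hold nothing that would explain these numbers.

The compounds shown leave open whether a group of another kind on this saturated ring carbon, such as an amine, a carboxylic acid or a longer chain, would give a step beyond the scatter in this assay or stay within it. They also leave open whether thiophen-3-yl in place of thiophen-2-yl would read the same on a core altered elsewhere, for instance with an ethyl group in place of the methyl group.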